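A few compounds are considered here, and "the series" means these few. Any claim that something is new, unique, unknown or untested is made for them only; others in the source may bear on it.

The shared core of these three compounds carries a phenyl group that differs only in what sits on it. Compound 1 has the structure `COc1nc(-c2cc3ccccc3o2)cc(-c2ccccc2)c1C#N`, compound 2 has the structure `COc1nc(-c2cc3ccccc3o2)cc(-c2ccc(Cl)cc2)c1C#N`, and compound 3 has the structure `COc1nc(-c2cc3ccccc3o2)cc(-c2ccc(Br)cc2)c1C#N`. In a functional assay on aorta (strain Wistar) for inhibition, with Thoracic aorta (Rattus norvegicus) as the target (on this read-out higher numbers stand for weaker inhibition and lower numbers for stronger inhibition), compound 1 gives 232000 nM, compound 2 gives 286000 nM, and compound 3 gives 298000 nM. None of these numbers separates from the others: the change a 1.2-fold higher number from compound 1 to compound 2 (0.09 log units; within the scatter), the change a 1.3-fold higher number from compound 1 to compound 3 (0.11 log units; within the scatter), and the change a 1.0-fold higher number from compound 2 to compound 3 (0.02 log units; within the scatter) all lie inside the usual scatter, so compound 3 stands together with compounds 1 and 2 rather than apart from them.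

Compound 4, with the structure `COc1nc(-c2cc3ccccc3o2)cc(-c2ccc(F)cc2)c1C#N`, comes from compound 3 by a single exchange: fluoro in place of bromo on an aromatic carbon. Among the measured compounds shown here, the steps that bear on this are those that swapped the group on this same aromatic carbon, namely the change a 1.3-fold higher number from compound 1 to compound 3 (0.11 log units; within the scatter) and the change a 1.0-fold higher number from compound 2 to compound 3 (0.02 log units; within the scatter), both of which left this assay essentially unmoved. Since hydrogen, chloro and bromo at this position all gave numbers within the scatter, the expectation for compound 4 is a step of a 1.1-fold lower number from compound 3 to compound 4 (0.06 log units; within the scatter), that is, no movement beyond the scatter. Compound 4 is therefore estimated at 260000 nM, with a range from 130000 nM to 520000 nM.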

Compound 4, half-maximal inhibitory concentration: 321000 nM
Estimate against measurement, compound 4: 1.2-fold (0.09 log units) below; the measured number falls inside the stated range.
By their numbers in this assay, from the lowest: compounds 1, 2, 3 and 4 (each within the scatter of the next).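

The fluoro compound adds a fourth group on this aromatic carbon, para to a large group, and in this assay the exchange stays inside the scatter whichever group it replaces: a 1.1-fold higher number from compound 3 to compound 4 (0.03 log units; within the scatter) and a 1.1-fold higher number from compound 2 to compound 4 (0.05 log units; within the scatter) and also a 1.4-fold higher number from compound 1 to compound 4 (0.14 log units; within the scatter) all count as no real change. The earlier compounds shown here showed this for hydrogen, chloro and bromo only, whereas the four compounds now form a single cluster, with fluoro joining them and none of the four going against it. Nothing available here explains why these exchanges leave the number in place.

Going by these compounds, all four groups at this carbon are hydrogen or a single halogen, so it remains open whether an amine, a carboxylic acid, a methoxy group or a longer chain in the same place would move the number beyond the scatter. On these data alone, the methoxy group, the nitrile and the rest of the shared core are identical in all four compounds, so what changes there would do to this read-out also remains open.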